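Swapping the Aryl Tail: From Compound 2 to Compound 3

A few compounds are considered here, and "the series" means these few. Any claim that something is new, unique, unknown or untested is made for them only; others in the source may bear on it.

Among the compounds with values here, compound 2 `Cc1cc(C)c(NC(=O)C(C)(C)CCCc2ccc(CC(C)C)cc2)c2c1CC(C)(C)O2` holds the lowest number of the two measured so far in an assay for inhibition of acyl-CoA:cholesterol acyltransferase (Oryctolagus cuniculus), using microsomes (a higher number here means a weaker inhibitor, a lower number a stronger inhibitor), giving 40 nM; compound 1 `Cc1cc(C)c(NC(=O)C(C)(C)CCCCCc2ccccc2)c2c1CC(C)(C)O2` gives 120 nM. Within the data shown here, the single measured step, a 3.0-fold lower number from compound 1 to compound 2 (0.48 log units; beyond the scatter), concerns the group at the far end of the chain. Compound 3 `Cc1cc(C)c(NC(=O)C(C)(C)CCCOc2ccc(Cl)cc2)c2c1CC(C)(C)O2` differs from compound 2 by 4-chlorophenoxy in place of 4-isobutylphenyl on a saturated chain carbon, four bonds along the chain from a carbonyl carbon. Among the measured compounds shown here, no measured step tests this exchange, so only a modest shift seems warranted, and compound 3 is expected near 100 nM, within 30 nM to 400 nM. That corresponds to an expected step of a 2.5-fold higher number from compound 2 to compound 3 (0.40 log units; beyond the scatter).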

Compound 3, half-maximal inhibitory concentration: 260 nM
Beside the measured number, compound 3's estimate is 2.6-fold (0.41 log units) below it; the range from low to high includes it.
By their numbers in this assay, from the lowest: compound 2; then compound 1; then compound 3.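

Swapping the tail on this saturated chain carbon to 4-chlorophenoxy gives, in this assay, a 6.5-fold higher number from compound 2 to compound 3 (0.81 log units; beyond the scatter), and the change from the phenethyl tail gives a 2.2-fold higher number from compound 1 to compound 3 (0.34 log units; beyond the scatter). Both steps point the same way, so the 4-chlorophenoxy tail gives the weakest inhibition among these three compounds, behind both tails made of carbon alone. Nothing available explains this rise. As far as these compounds go, the oxygen and the chlorine enter together, so which of them drives the change stays open. A tail ending in an amine or a carboxylic acid also remains untested among the compounds shown here.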